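The source may hold more compounds than are shown below. What is called first, only, known or untested is meant among the compounds shown, and "the series" means these compounds.

Of the compounds shown here, two built on one shared core have been tested in a functional assay on NCI-H460 cells (Homo sapiens) for inhibition, read by sulforhodamine B assay, with a stated time of 48 h; on this read-out lower numbers stand for stronger inhibition of growth and higher numbers for weaker inhibition of growth. Compound 1 `COC(=O)c1sc2cc(-c3cccnc3)cnc2c1N` gives in this assay only a limit, > 112000 nM, and that is a limit of the assay rather than a number. Compound 2 `COC(=O)c1sc2cc(-c3ccc(C(C)=O)cc3)cnc2c1N` gives in this assay likewise only a limit, > 150000 nM. Both values shown are limits, as in the limit of > 112000 nM in this assay, at which 1 of the 2 values shown sits, and (the limit of > 150000 nM in this assay, at which 1 of the 2 values shown sits), and compound 2 stands at one of them, so nothing stronger than a limit is known for either compound. Compound 3 `COC(=O)c1sc2cc(-c3ccc(N)cc3)cnc2c1N` differs from compound 2 by amino in place of acetyl on an aromatic carbon. No measured step on this kind of change exists among the compounds shown. The expectation is a step of a number no higher from compound 2 to compound 3 (the limit leaves the size open) that stays within the scatter, with compound 3 most likely remaining at a limit. Compound 3 is therefore estimated at 150000 nM, in a range from 40000 nM to 500000 nM.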

Compound 3, concentration for 50% growth inhibition: 37100 nM
Beside the measured number, compound 3's estimate is 4.0-fold (0.61 log units) above it; the whole stated range lies above it.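

In this assay, amino in place of acetyl on this six-membered aromatic ring of carbon only gives an at least 4.0-fold lower number from compound 2 to compound 3 (0.60 log units; beyond the scatter), and 4-aminophenyl in place of pyridin-3-yl gives an at least 3.0-fold lower number from compound 1 to compound 3 (0.47 log units; beyond the scatter). The number in this assay therefore does respond to the group at this place on the shared core, and compound 3 is the only one of the three whose value is a number rather than a limit. Compound 2 has only a limit, so its step shows a smallest size and not a true size: the limit of > 150000 nM in this assay, at which 1 of the 3 values shown sits.

On these data alone, whether a hydroxyl group, a methylamino group or a carboxylic acid at the same place would give a lower or a higher number stays open. Compound 1 also has only a limit, so the true size of its step stays open too: the limit of > 112000 nM in this assay, at which 1 of the 3 values shown sits.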